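This account rests on a few compounds, and the source may have more. Where it says the series, first, only, none or still open, it means among the compounds named here.

Measured in a toxicity assay on cells (Mesenchymal stem cells, Homo sapiens) for cytotoxicity, read by CCK-8 assay, with a stated time of 48 h; on this read-out lower numbers stand for stronger inhibition and higher numbers for weaker inhibition:

- Compound 1 `O=C(Nc1nc(-c2ccc(F)cc2)cs1)c1cc(=O)c2ccccc2o1`: 7560 nM
- Compound 2 `O=C(Nc1nc2cc(F)ccc2s1)c1cc(=O)c2ccccc2o1`: 4340 nM

Within the data shown here, compound 1 stands level with compound 2, the only other measured compound, as their two values lie within the usual scatter of each other. Compound 3 `O=C(Nc1nc(-c2ccc(OC(F)(F)F)cc2)cs1)c1cc(=O)c2ccccc2o1` has not yet been measured. It carries trifluoromethoxy in place of fluoro on an aromatic carbon of compound 1, para to a large group: trifluoromethoxy in place of fluoro on an aromatic carbon. Among the measured compounds shown here, no measured pair shows this change, so no step beyond the scatter is expected in this assay. The expected change is a 1.3-fold lower number from compound 1 to compound 3 (0.10 log units; within the scatter), which stays within the scatter. For compound 3 the estimate is 6000 nM, with an expected range from 2200 nM to 16000 nM.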

Compound 3, half-maximal inhibitory concentration: 17700 nM
Estimate against measurement, compound 3: 3.0-fold (0.47 log units) below; measured number above the stated range.
By their numbers in this assay, from the lowest: compounds 2 and 1 (each within the scatter of the next); then compound 3.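

In this assay, this place on the ring is not indifferent to what it carries: trifluoromethoxy in place of fluoro gives a 2.3-fold higher number from compound 1 to compound 3 (0.37 log units; beyond the scatter), a modest move towards weaker inhibition of the cells. Among these compounds, the earlier compounds offered no single-place change, so this is the first step that can be read. No measurement here gives a reason for the step.

As far as these compounds go, whether other groups at this place would also raise the number stays open. An amine or a carboxylic acid there would test whether the trend extends beyond this one replacement.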